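A few compounds are considered here, and "the series" means these few. Any claim that something is new, unique, unknown or untested is made for them only; others in the source may bear on it.

Measured so far:
Compound 1, `C/C(=N/NC(=S)N(Cc1ccccc1)Cc1ccccc1)c1ccc(O)cc1`: in an ADME assay on Vero cells (Chlorocebus sabaeus) for cytotoxicity, read by MTT assay, with a stated time of 72 h (on this read-out lower numbers stand for higher toxicity in this test and higher numbers for lower toxicity in this test), compound 1 gives 160000 nM.
Compound 2, `C=CCN(CC=C)C(=S)N/N=C(/C)c1ccc([N+](=O)[O-])cc1`: in this assay compound 2 reaches only a limit, < 197000 nM.
Compound 3, `C/C(=N/NC(=S)N(Cc1ccccc1)Cc1ccccc1)c1ccc([N+](=O)[O-])cc1`: in this assay compound 3 reaches only a limit, < 150000 nM.

Compound 1 and compound 3 share one core and differ in a single place, (hydroxy in place of nitro on an aromatic carbon). In this assay this change made an at least 1.0-fold higher number from compound 3 to compound 1 (0.02 log units; that floor lies within the scatter). The step is only a floor because compound 3 sits at the limit of < 150000 nM in this assay, at which 1 of the 3 values shown sits, so the true size of the step is not fixed by these two values.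

Compound 2 carries a different core; the difference between the two cores of compound 2 and compound 3 is not broken down here. Compound 2 itself stands at the limit of < 197000 nM in this assay, at which 1 of the 3 values shown sits, which is a limit and not a number.

Compound 4, `C=CCN(CC=C)C(=S)N/N=C(/C)c1ccc(O)cc1`, has not yet been measured in this assay. It stands to compound 2 exactly as compound 1 stands to compound 3: hydroxy in place of nitro on an aromatic carbon. The surroundings of the place are described in the same words for both pairs, so this is the same change made on the second core.

From compound 2 to compound 4 the step in this assay is expected to be a step that the limit leaves unreadable from compound 2 to compound 4, resting on the earlier step of an at least 1.0-fold higher number from compound 3 to compound 1 (0.02 log units; that floor lies within the scatter), which gave only a floor within the scatter. Compound 2 offers only a limit, < 197000 nM, so the starting point is itself uncertain. Compound 4 is therefore expected to give about 150000 nM in this assay, with a likely span from 60000 nM to 300000 nM.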

Compound 4, half-maximal cytotoxic concentration: 216000 nM
Estimate against measurement, compound 4: 1.4-fold (0.16 log units) below; measured number inside the range.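

In this assay, hydroxy in place of nitro on an aromatic carbon of the second core gives an at least 1.0-fold higher number from compound 2 to compound 4 (0.03 log units; that floor lies within the scatter), so this core too yields only a floor and not a measured step. Set beside the first core, the result is a second floor of the same kind, and no size can be compared across the two cores: the same change on two cores in this assay, an at least 1.0-fold higher number (0.02 log units; that floor lies within the scatter) from compound 3 to compound 1 and an at least 1.0-fold higher number (0.03 log units; that floor lies within the scatter) from compound 2 to compound 4; the limit leaves it open whether they differ. The two pairs are compatible with the change carrying from one core to the other, but neither a shared step size nor a real rise in the number on either core is shown, since the nitro compound in each pair stands at a limit and not at a number: the limit of < 197000 nM in this assay, at which 1 of the 4 values shown sits.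

The compounds shown leave open how other groups on the same aromatic carbon, such as an amine, a methoxy group or a carboxylic acid, would read in this assay. They also leave open whether the nitro-to-hydroxy change behaves alike on a core bearing a longer alkyl chain, and how large the step is on any core once a nitro compound has an exact number rather than a limit.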